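Swapping pyridin-3-yl for hydroxymethyl on the shared core

The compounds below may be only part of what the source reports. "The series", "measured", "known", "first", "only" and "open" are said of these compounds alone.

- compound 1 `CCCCCCc1cn(CCCN2C(=O)COc3ccccc32)nn1`: 100 nM
- compound 2 `O=C1COc2ccccc2N1CCCn1cc(-c2ccccn2)nn1`: 10000 nM
- compound 3 `O=C1COc2ccccc2N1CCCn1cc(-c2cccnc2)nn1`: > 100000 nM (a limit, not a number)

All three were tested in a functional assay on HeLa cells (Homo sapiens) for antiproliferative activity, read by sulforhodamine B assay, with a stated time of 48 h (on this read-out lower numbers stand for stronger inhibition of growth and higher numbers for weaker inhibition of growth), and compound 3 gives only a limit there. Compound 4 `O=C1COc2ccccc2N1CCCn1cc(CO)nn1` carries hydroxymethyl in place of pyridin-3-yl on an aromatic carbon. Three measured steps at this same carbon bear on it: a 100-fold higher number from compound 1 to compound 2 (2.00 log units; beyond the scatter) and an at least 1000-fold higher number from compound 1 to compound 3 (3.00 log units; beyond the scatter), both large, and an at least 10-fold higher number from compound 2 to compound 3 (1.00 log units; beyond the scatter), at least modest. Compound 4 lacks the hexyl of compound 1 as well, so it should stay far weaker than compound 1. Compound 2 at 10000 nM shows that a group other than hexyl can still give a number, so a modest move to a lower number is expected in this assay. Another limit remains possible for compound 4. The expected step is an at least 3.3-fold lower number from compound 3 to compound 4 (0.52 log units; beyond the scatter). The estimate for compound 4 is 30000 nM. Its expected range runs from 5000 nM to 100000 nM.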

Compound 4, concentration for 50% growth inhibition: 7300 nM
Compound 4: middle estimate off by 4.1-fold (0.61 log units), on the high side, and the stated range covers the measured number.
By their numbers in this assay, from the lowest: compound 1; then compounds 4 and 2 (each within the scatter of the next). At a limit, above all of these: compound 3.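

Hydroxymethyl on this carbon gives an at least 13-fold lower number from compound 3 to compound 4 (1.13 log units; beyond the scatter), so an aromatic ring is not needed here for a measurable number. Against pyridin-2-yl, it shows a 1.4-fold lower number from compound 2 to compound 4 (0.14 log units; within the scatter), yet hexyl stays clearly ahead, with a 73-fold higher number from compound 1 to compound 4 (1.86 log units; beyond the scatter). The step from compound 3 starts from a limit, not a number: the limit of > 100000 nM in this assay, at which 1 of the 4 values shown sits.

The compounds shown leave open whether chain length alone tracks the number, which a propyl or an octyl chain on this carbon could test. An aminomethyl group in place of hydroxymethyl could show how much the hydroxy itself matters.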